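Bromo for Cyano at a Different Place on the Ring

This account rests on a few compounds, and the source may have more. Where it says the series, first, only, none or still open, it means among the compounds named here.

Of the compounds shown here, three have been measured in a functional assay on the whole organism for inhibition, with Rattus norvegicus as the target, at a dose of 30 mg/kg; on this read-out higher numbers stand for more inhibition at the one dose given (going by the name of the read-out) and lower numbers for less inhibition. Compound 1 `Brc1cccc(-c2nc3ncccc3o2)c1` gives 23% in this assay. Compound 2 `N#Cc1cccc(-c2nc3ncccc3o2)c1` gives 21% in this assay. Compound 3 `N#Cc1ccccc1-c1nc2ncccc2o1` gives 62% in this assay, the highest of the three, and its distance from both compound 1 and compound 2 lies beyond the usual scatter of repeated measurements.

Compound 1 and compound 2 differ in one place: bromo in place of cyano on an aromatic carbon. The step this made was a number 2 percentage points higher from compound 2 to compound 1 (within the scatter), so exchanging these two groups left the read-out essentially unchanged. Compound 3 and compound 2 are built from the same atoms joined differently; the difference between the two cores is not broken down here.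

Compound 4 `Brc1ccccc1-c1nc2ncccc2o1` has not yet been measured in this assay. It differs from compound 3 in one place: bromo in place of cyano on an aromatic carbon. Within the data shown here, this is the same kind of change as the one from compound 2 to compound 1, but the place is not identical: on compound 1 the group sits meta to a group of 9 heavy atoms, whereas on compound 4 it sits ortho to a group of 9 heavy atoms.

Because the earlier step was a number 2 percentage points higher from compound 2 to compound 1 (within the scatter), the expected step is a number 2 percentage points lower from compound 3 to compound 4 (within the scatter), again within the scatter. Compound 4 is therefore estimated to give 60% in this assay, with a likely range from 40% to 78%; the wider range reflects that the change is at a new place and the earlier step stands alone.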

Compound 4, a percentage reported as inhibition, in the whole organism at one dose (the size of the read-out at that dose, not a potency): 24%
For compound 4 the middle estimate is 36 percentage points above the measured one; the whole stated range lies above it.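

In this assay, putting bromo in place of cyano on the core of compound 3 gave a number 38 percentage points lower from compound 3 to compound 4 (beyond the scatter), so an exchange that changed little on one core cannot be assumed to change little on another. Set side by side, the two results disagree: the same change on two cores in this assay, a number 2 percentage points higher (within the scatter) from compound 2 to compound 1 and a number 38 percentage points lower (beyond the scatter) from compound 3 to compound 4, 40 percentage points apart, beyond the scatter of two such steps What this does not show is the reason for the disagreement: each core offers only one such pair, and these two pairs cannot tell whether the cyano group itself matters on the core of compound 3 or whether other groups ortho to a group of 9 heavy atoms would do as well.

The compounds shown leave open whether another group at this place, such as an amine, a methoxy group or a carboxylic acid, would stay close to compound 3 or fall towards compound 4. Going by these compounds, a single dose is all that is given here, and how compound 3 and compound 4 would compare at other doses also stays open.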